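Chloro substitution on the fused core: compound 3 outlook

A few compounds are considered here, and "the series" means these few. Any claim that something is new, unique, unknown or untested is made for them only; others in the source may bear on it.

Measured so far:
compound 1, `ClCc1cccc(Cn2cnc3ncnc(Cl)c32)c1` — 39800 nM
compound 2, `ClCc1cccc(Cn2cnc3c(Cl)nc(Cl)nc32)c1` — 10000 nM

In a functional assay on A549 cells (Homo sapiens) for cytotoxicity, read by sulforhodamine B assay, with a stated time of 48 h (on this read-out lower numbers stand for stronger inhibition of growth and higher numbers for weaker inhibition of growth), compound 1 gives 39800 nM, the highest of the two numbers in hand. Compound 2 gives 10000 nM, a lower number, and the gap between the two lies beyond the usual scatter. Both carry the same benzyl side chain with a chloromethyl group; they differ only in the number and placement of chloro groups on the fused core.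

Compound 3, `ClCc1cccc(Cn2cnc3nc(Cl)nc(Cl)c32)c1`, has not yet been measured in this assay. Relative to compound 1 the change is chloro in place of hydrogen on an aromatic carbon; the new chloro group sits between two ring nitrogen atoms, on the six-membered aromatic ring of the fused system.

Among the measured compounds shown here, no step between measured compounds covers this exact change. What the two numbers show is that adding a second chloro group to the core went with a lower number for compound 2 than for compound 1. A step in the same direction is expected for compound 3, beyond the scatter but of uncertain size, since the second chloro group in compound 3 enters a different position. The step from compound 1 to compound 3 is estimated at a 3.1-fold lower number from compound 1 to compound 3 (0.49 log units; beyond the scatter). For compound 3 the estimate in this assay is 13000 nM, with a range from 5000 nM to 32000 nM.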

Compound 3, concentration for total growth inhibition: 25700 nM
Compound 3: the middle estimate sits 2.0-fold (0.30 log units) below what was measured; the measured number falls inside the stated range.
By their numbers in this assay, from the lowest: compound 2; then compounds 3 and 1 (each within the scatter of the next).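

In this assay, chloro in place of hydrogen on an aromatic carbon between two ring nitrogen atoms gives a 1.5-fold lower number from compound 1 to compound 3 (0.19 log units; within the scatter), so compound 1 and compound 3 cannot be told apart at this position. Among the compounds shown here, the earlier pair showed only that compound 2, at 10000 nM, carried a second chloro group on the core and had a lower number than compound 1; compound 3 shows that a second chloro group on the core does not by itself bring a step beyond the scatter, and that its placement has to be considered along with its presence. No measurement at hand bears on the reason for this result.

The compounds shown leave open whether this position tolerates anything other than hydrogen or chloro, for example an amine or a methoxy group, and whether either would give a step beyond the scatter. They also leave open how much of the growth inhibition depends on the chloromethyl group of the shared benzyl side chain, which a plain methyl or a hydroxymethyl group in its place would test.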